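A few compounds are considered here, and "the series" means these few. Any claim that something is new, unique, unknown or untested is made for them only; others in the source may bear on it.

Compound 1 `O=[N+]([O-])c1ccc(-c2nnnn2CCN2CCC(Cc3ccccc3)CC2)cc1` gives 1980 nM in an assay on HEK293 cells for inhibition of sodium-dependent dopamine transporter (Homo sapiens), read by scintillation counting; a higher number here means a weaker inhibitor, a lower number a stronger inhibitor.
Compound 2 `Clc1ccccc1-c1nnnn1CCCN1CCC(Cc2ccccc2)CC1` gives 6550 nM in this assay.
Compound 3 `Clc1cccc(-c2nnnn2CCCN2CCC(Cc3ccccc3)CC2)c1Cl` reaches only a limit in this assay, > 10000 nM.
Compound 4 `c1ccc(CC2CCN(CCCn3nnnc3-c3cccc4ccccc34)CC2)cc1` has not yet been measured in this assay.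

Compound 2 holds the higher of the two plain numbers, with compound 1 lying below it beyond the usual scatter. Compound 3 sits at the limit of > 10000 nM in this assay, at which 1 of the 3 values shown sits.

The step to compound 4 is naphthalen-1-yl in place of 2-chlorophenyl on an aromatic carbon. Going by the values given here, the only measured step that touches this part of the molecule is an at least 1.5-fold higher number from compound 2 to compound 3 (0.18 log units; that floor lies within the scatter), and it says nothing direct about swapping in a fused second ring. Compound 4 is therefore expected to stay close to compound 2, with a 1.1-fold higher number from compound 2 to compound 4 (0.03 log units; within the scatter). The estimate for compound 4 is 7000 nM, within 2500 nM to 20000 nM.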

Compound 4, half-maximal inhibitory concentration: 6000 nM
For compound 4 the middle estimate is 1.2-fold (0.07 log units) above the measured one; the range from low to high includes it.
By their numbers in this assay, from the lowest: compound 1; then compounds 4 and 2 (each within the scatter of the next). At a limit, above all of these: compound 3.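

At this position, naphthalen-1-yl, with its second aromatic ring and no chlorine, does as well as 2-chlorophenyl in this assay: a 1.1-fold lower number from compound 2 to compound 4 (0.04 log units; within the scatter). The chlorine is therefore not needed to hold binding at this modest level. The other step, an at least 1.6-fold lower number from compound 3 to compound 4 (0.22 log units; that floor lies within the scatter), is only a floor, since compound 3 holds a limit and not a number: the limit of > 10000 nM in this assay, at which 1 of the 4 values shown sits.

As far as these compounds go, it remains open whether naphthalen-2-yl, a saturated cyclohexyl ring or a phenyl ring carrying an amine would move the number beyond the scatter.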